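The source may report more compounds than this note shows. Statements on the series, on what has been measured and on what is new or still open speak of the compounds shown alone.

In a functional assay on A549 cells (Homo sapiens) for inhibition, read by CCK-8 assay, with a stated time of 72 h, tested at 8 uM (a lower number here means less inhibition of growth, a higher number more inhibition of growth at the concentration tested), compound 1 (`COc1ccc(SCc2ccc(C(=O)Nc3ccccc3N)cc2)cc1`) gives 70.7% as the working reference. Compound 2 (`COc1ccc(SCc2ccc(C(=O)Nc3ccccc3N)cc2)cc1OC`) gives 80.1% and compound 3 (`CC(C)(C)c1ccc(SCc2ccc(/C=C/C(=O)Nc3ccccc3N)cc2)cc1`) gives 79.8% in the same read-out. All three numbers lie within the usual scatter of each other, so compound 1 cannot be separated from the other two.

Compound 4 (`Nc1ccccc1NC(=O)c1ccc(CSc2ccc(Cl)cc2)cc1`) has not yet been measured. Its difference from compound 1 is chloro in place of methoxy on an aromatic carbon and amounts to chloro in place of methoxy on an aromatic carbon.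

Within the data shown here, only one measured step bears on this change: a number 9.4 percentage points higher from compound 1 to compound 2 (within the scatter) for methoxy in place of hydrogen on an aromatic carbon, which stays within the scatter. Among the measured compounds shown here, compound 3 differs from compound 1 in more than one place and gives no clean step. For the measured compounds named here, no measured compound carries chloro, so the evidence is thin.

No step beyond the scatter is expected in this assay, and no direction can be assigned. The expected result is a number 1.3 percentage points higher from compound 1 to compound 4 (within the scatter) as an estimate. For compound 4 the estimated value is 72% with an expected range from 60% to 84% in this read-out.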

Compound 4, percent growth inhibition at one concentration: 50.4%
Compound 4: the middle estimate sits 21.6 percentage points above what was measured; measured number outside the range, below it.
By their numbers in this assay, from the lowest: compound 4; then compounds 1, 3 and 2 (each within the scatter of the next).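

Chloro in place of methoxy, on the aromatic carbon para to a large group, gives the first step in the series that clears the scatter in this assay: a number 20.3 percentage points lower from compound 1 to compound 4 (beyond the scatter). Among these compounds, this position is therefore not indifferent to its substituent, something the only earlier step, a number 9.4 percentage points higher from compound 1 to compound 2 (within the scatter), could not show, since it stayed within the scatter and involved a different ring carbon. No measurement at hand accounts for the size or direction of this step.

With a single swap, the lower number cannot be assigned to the loss of methoxy or to the arrival of chloro. Plain hydrogen, fluoro, methyl or an amine on this same carbon would separate the two readings, and whether the same swap holds on the core of compound 3 remains open.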